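Tail change on the shared core

A few compounds are considered here, and "the series" means these few. Any claim that something is new, unique, unknown or untested is made for them only; others in the source may bear on it.

Of the compounds shown here, three on one shared core have been measured in a functional assay on MCF7 cells (Homo sapiens) for antiproliferative activity, read by MTT assay, with a stated time of 72 h; a higher number here means a weaker inhibitor, a lower number a stronger inhibitor. Compound 1, `COc1cc2ncnc(N3CCCc4ccccc43)c2cc1NC(=O)/C=C/C(C)C`, gives 4290 nM in this assay. Compound 2, `CC(C)/C=C/C(=O)Nc1cc2c(N3CCCc4ccccc43)ncnc2cc1O[C@@H]1CCOC1`, gives 4680 nM; among the three numbers it stands second highest, nearest to compound 1, and the move from compound 1 to compound 2 was a 1.1-fold higher number from compound 1 to compound 2 (0.04 log units; within the scatter). Compound 3, `COc1cc2ncnc(N3CCCc4ccccc43)c2cc1NC(=O)/C=C/CN1CCC(CO)CC1`, gives 5740 nM in this assay, and the move from compound 1 to compound 3 was a 1.3-fold higher number from compound 1 to compound 3 (0.13 log units; within the scatter).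

Compound 4, `CN1CCN(C/C=C/C(=O)Nc2cc3c(N4CCCc5ccccc54)ncnc3cc2O[C@@H]2CCOC2)CC1`, is compound 2 with one change: (4-methylpiperazin-1-yl)methyl in place of isopropyl on a double-bonded chain carbon bound to a double-bonded chain carbon. Within the data shown here, the measured step that bears on it is the one from compound 1 to compound 3, where a ring-bearing methyl group took the place of the same isopropyl at the same place and the outcome was a 1.3-fold higher number from compound 1 to compound 3 (0.13 log units; within the scatter). On that basis the account expects no step beyond the scatter in this assay, with a slight lean toward a higher number, and the expected step is a 1.2-fold higher number from compound 2 to compound 4 (0.08 log units; within the scatter). Compound 4 is therefore estimated at 5600 nM in this assay, within a range from 2500 nM to 12500 nM.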

Compound 4, half-maximal inhibitory concentration: 7180 nM
Estimate against measurement, compound 4: 1.3-fold (0.11 log units) below; measured number inside the range.
By their numbers in this assay, from the lowest: compounds 1, 2, 3 and 4 (each within the scatter of the next).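

In this assay, placing (4-methylpiperazin-1-yl)methyl on the double-bonded chain carbon in place of isopropyl gives a 1.5-fold higher number from compound 2 to compound 4 (0.19 log units; within the scatter), so a second ring-bearing tail at this place also stays inside the scatter. Read with a 1.3-fold higher number from compound 1 to compound 3 (0.13 log units; within the scatter), it shows that this kind of exchange stays within the scatter with either methyl or oxolan-3-yl on the oxygen on the aromatic ring, and with either of the two ring-bearing tails tested. Nothing given here explains how the numbers at this place behave.

The compounds shown leave open whether a tail with a dimethylamino group or a morpholine ring on the same chain carbon would also stay within the scatter. They also leave open whether any group at this place can move the number beyond the scatter.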